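A few compounds are considered here, and "the series" means these few. Any claim that something is new, unique, unknown or untested is made for them only; others in the source may bear on it.

Compound 1, with the structure `Nc1ncc(-c2ccc(C(=O)N3CCC(O)CC3)cc2)nc1-c1ccc(C(F)(F)F)cc1`, was measured in a physicochemical assay for solubility, read by HPLC, using the shake flask method, with a stated time of 2 h, at pH 2 (on this read-out higher numbers stand for higher solubility and lower numbers for lower solubility), and gave 119000 nM. Two related compounds give a frame for it. Compound 2, `Nc1ncc(-c2ccc(C(=O)N3CC[C@H](O)C3)cc2)nc1-c1ccc(C(F)(F)F)cc1`, gives 93000 nM in this assay, and compound 3, `CNC(=O)c1ccc(-c2nc(-c3ccc(C(N)=O)cc3)cnc2N)cc1`, gives 186000 nM. Compound 1 therefore sits in the middle of these three numbers, but both gaps are within the usual scatter of this kind of measurement, so none of the three can be said to be more or less soluble than the others.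

The compound still to be measured is compound 4, `Nc1ncc(-c2ccc(C(=O)N3CC(O)C3)cc2)nc1-c1ccc(C(F)(F)F)cc1`. It is made from compound 1 by a single change: 3-hydroxyazetidin-1-yl in place of 4-hydroxypiperidin-1-yl on a carbonyl carbon. The closest guide is the step already seen, in which a five-membered ring took the place of the six-membered one: a 1.3-fold lower number from compound 1 to compound 2 (0.11 log units; within the scatter). Going to a four-membered ring is a further shortening of the same kind, and nothing in the data points to a departure from that pattern, so the step is expected to be small, a 1.1-fold lower number from compound 1 to compound 4 (0.05 log units; within the scatter), with no clear direction beyond the scatter. Compound 4 is therefore estimated to give 105000 nM in this assay, most likely between 55000 nM and 200000 nM.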

Compound 4, solubility: 110000 nM
Estimate against measurement, compound 4: 1.0-fold (0.02 log units) below; the measured number falls inside the stated range.
By their numbers in this assay, from the lowest: compounds 2, 4, 1 and 3 (each within the scatter of the next).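

In this assay, the 4-hydroxypiperidin-1-yl group on the carbonyl carbon can be exchanged for the four-membered 3-hydroxyazetidin-1-yl group with no change that stands out from the scatter (a 1.1-fold lower number from compound 1 to compound 4 (0.03 log units; within the scatter)). Among these compounds, the comparison with the five-membered ring reads the same way (a 1.2-fold higher number from compound 2 to compound 4 (0.07 log units; within the scatter)), so compound 1, compound 2 and compound 4 cannot be told apart on this read-out, whereas the earlier compounds offered only a single ring exchange at this position. Nothing available here gives a measured property of these groups that could explain how the numbers fall.

All three of these rings carry a hydroxyl group, so the compounds shown leave open what this read-out would do if that hydroxyl were replaced on the same ring by an amine, a carboxylic acid or a methoxy group. They also leave open whether a ring-free amide, such as the plain dimethylamide, would fall within the scatter of these compounds or clearly apart from them.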